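The source may hold more compounds than are shown below. What is called first, only, known or untested is meant among the compounds shown, and "the series" means these compounds.

Measured so far:
compound 1 `Cc1ccc(-c2cn(C/C=C3\OC(=O)C(OCc4ccccc4)=C3OCc3ccccc3)nn2)cc1` – > 100000 nM
compound 2 `CCCCCCCCCCc1cn(C[C@H](O)[C@H]2OC(=O)C(OCc3ccccc3)=C2OCc2ccccc2)nn1` – 28800 nM
compound 3 `O=C1O[C@H]([C@@H](O)Cn2cc(-c3cc(F)cc(F)c3)nn2)C(OCc2ccccc2)=C1OCc1ccccc1` – 48200 nM

In a functional assay on HCT-116 cells (Homo sapiens) for antiproliferative activity, read by MTT assay, with a stated time of 72 h (a lower number here means a stronger inhibitor, a higher number a weaker inhibitor), compound 1 returns only a limit, > 100000 nM. Compound 2 gives 28800 nM and compound 3 gives 48200 nM; the step of a 1.7-fold higher number from compound 2 to compound 3 (0.22 log units; within the scatter) stays within the scatter. Compound 1 thus stands at the limit of this assay (the limit of > 100000 nM in this assay, at which 1 of the 3 values shown sits), with no number of its own.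

Compound 4 `O=C1O/C(=C\Cn2cc(-c3cccc(O)c3)nn2)C(OCc2ccccc2)=C1OCc1ccccc1` differs from compound 1 in one place: 3-hydroxyphenyl in place of 4-methylphenyl on an aromatic carbon. For the measured compounds named here, none of the measured steps covers this change; the only one available exchanges a decyl for an aryl group on a different core and was within the scatter. The author therefore expects no movement beyond the scatter and that compound 4 stays at the limit, estimated at 120000 nM (40000 nM to 400000 nM), a step that the limit leaves unreadable from compound 1 to compound 4.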

Compound 4, half-maximal inhibitory concentration: 63600 nM
Beside the measured number, compound 4's estimate is 1.9-fold (0.28 log units) above it, and the stated range covers the measured number.
By their numbers in this assay, from the lowest: compounds 2, 3 and 4 (each within the scatter of the next, the first and the last beyond it). At a limit, above all of these: compound 1.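

Compound 1 gives only a limit, not a number: the limit of > 100000 nM in this assay, at which 1 of the 4 values shown sits.

Compound 4 shows that the core of compound 1, with an aryl group on this aromatic carbon, can return a number in this assay. On these data alone, the exchange of 4-methylphenyl for 3-hydroxyphenyl comes out as an at least 1.5-fold lower number from compound 1 to compound 4 (0.19 log units; that floor lies within the scatter), so only a floor can be read and the full size of the change stays unknown.

The compounds shown leave open whether an amine or a carboxylic acid in place of the hydroxyl would give a number apart from compound 4. They also leave open whether 3-hydroxyphenyl would behave alike on the core of compound 3.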